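The source may report more compounds than this note shows. Statements on the series, on what has been measured and on what is new or still open speak of the compounds shown alone.

Measured so far:
Compound 1 `COc1cc2ncnc(-n3nc(-c4ccccn4)nc3N)c2cc1N`: "not determined" (no result reported)
Compound 2 `COc1cc2ncnc(-n3nc(-c4ccccn4)nc3N)c2cc1OCCCN(C)C`: > 25000 nM

In an ADME assay on BJ cells (Homo sapiens) for cytotoxicity, with a stated time of 72 h (a higher number here means that more compound is needed for the effect, a lower number that less compound is needed), compound 2 gives > 25000 nM, which is a limit of the assay and not a number. Compound 3 `COCCOc1cc2c(-n3nc(-c4ccccn4)nc3N)ncnc2cc1OC` carries methoxy in place of (dimethylamino)methyl on a saturated chain carbon, two bonds along the chain from an oxygen on an aromatic ring. Among the measured compounds shown here, no measured pair shows what this change does in this assay. The expected step, a number no higher from compound 2 to compound 3 (the limit leaves the size open), is therefore none beyond the scatter, in either direction. For compound 3 the estimated value is 25000 nM, with an expected range of 10000 nM to 50000 nM.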

Compound 3, half-maximal effective concentration: > 13000 nM
Compound 3 was reported as a limit; the forecaster's own chance of this, stated with the estimate: 70%; the middle value lies beyond the limit too.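

Among the compounds shown here, compound 2 and compound 3 both stand only as limits in this assay, and no step between them can be read. The compounds shown leave open what concentration of either compound gives the half-maximal effect.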